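The compounds below may be only part of what the source reports. "The series", "measured", "known", "first", "only" and "open" are said of these compounds alone.

Compound 1 `CN(C)CCCCCSC1=Nc2ccccc2C(CC(=O)NCc2ccccc2)N1c1ccc(-c2ccc(F)cc2)cc1` gives 9060 nM in an assay on cells for inhibition of Voltage-dependent T-type calcium channel subunit alpha-1I (Homo sapiens), read by patch clamp; on this read-out higher numbers stand for weaker inhibition and lower numbers for stronger inhibition. Compound 2 `CN(C)CCCCCSC1=Nc2ccccc2C(CC(=O)NCc2ccccc2)N1c1ccc(-c2ccccc2)cc1` gives 1760 nM in this assay. Compound 3 `O=C(CC1c2ccccc2N=C(SCCCCCN2CCCC2)N1c1ccc(-c2ccc(F)cc2)cc1)NCc1ccccc1` gives 5100 nM in this assay.

Among these three, compound 1 stands with the highest number, meaning the weakest inhibition: the step of a 5.1-fold lower number from compound 1 to compound 2 (0.71 log units; beyond the scatter) lies beyond the scatter, while the step of a 1.8-fold lower number from compound 1 to compound 3 (0.25 log units; within the scatter) lies within it. Compound 4 `CN(C)CCCCCSC1=Nc2ccccc2C(CC(=O)NCc2ccc(F)cc2)N1c1ccc(-c2ccc(F)cc2)cc1` differs from compound 1 by fluoro in place of hydrogen on an aromatic carbon. Among the measured compounds shown here, no measured step touches this part of the structure; the one change at an aromatic carbon, removing a fluoro at a different aromatic ring, gave only a modest fall. With nothing that bears directly, the step of a 1.0-fold lower number from compound 1 to compound 4 (0.00 log units; within the scatter) is expected to be none beyond the scatter. Compound 4 is therefore estimated at 9000 nM, with a range from 4000 nM to 20000 nM.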

Compound 4, half-maximal inhibitory concentration: 960 nM
For compound 4 the middle estimate is 9.4-fold (0.97 log units) above the measured one, outside the stated range (below it).
By their numbers in this assay, from the lowest: compounds 4 and 2 (each within the scatter of the next); then compounds 3 and 1 (each within the scatter of the next).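

Putting 4-fluorobenzyl in place of benzyl gives a 9.4-fold lower number from compound 1 to compound 4 (0.97 log units; beyond the scatter) in this assay, so a single fluoro at this place clearly matters. The fluoro on the other aromatic ring acts in the opposite direction, since removing it gives a 5.1-fold lower number from compound 1 to compound 2 (0.71 log units; beyond the scatter), and the effect of a fluoro therefore depends on which ring carries it. No measurement at hand explains this difference.

Going by these compounds, it remains open whether chloro or methoxy at this place would act like fluoro, and whether 4-fluorobenzyl would lower the number in the same way on compound 2 or compound 3.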